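The compounds below may be only part of what the source reports. "The series", "measured", "known", "first", "only" and "open" are said of these compounds alone.

Compound 1 `CCNC(=O)c1noc(-c2cc(C(C)C)c(O)cc2O)c1-c1cc(COCC(N)=O)no1` carries a carbamoylmethoxy group and stands without a number in a functional assay on A2780 cells (Homo sapiens) for inhibition (on this read-out higher numbers stand for weaker inhibition and lower numbers for stronger inhibition), its entry reading "not determined" (no result reported). Compound 2 `CCCNCc1cc(-c2c(C(=O)NCC)noc2-c2cc(C(C)C)c(O)cc2O)on1` likewise has no result in this assay, its entry being "not determined" (no result reported). Only compound 3 `CCNC(=O)c1noc(-c2cc(C(C)C)c(O)cc2O)c1-c1cc(CN(CC)CC)no1` gives a number: in this assay compound 3 reaches 78 nM. Compound 4 `CCNC(=O)c1noc(-c2cc(C(C)C)c(O)cc2O)c1-c1cc(CN2CCCCC2)no1` differs from compound 1 by piperidin-1-yl in place of carbamoylmethoxy on a saturated chain carbon bound to an aromatic carbon. Within the data shown here, no measured step between compound 1 and compound 4 exists, so the size and direction of the change in this assay cannot be read from the data; compound 4 resembles compound 3 more closely than compound 1 does. Compound 4 is expected to lie near 60 nM, between 20 nM and 200 nM, because compound 3 gives 78 nM in this assay.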

Compound 4, half-maximal inhibitory concentration: 62 nM
Compound 4: middle estimate off by 1.0-fold (0.01 log units), on the low side; the range from low to high includes it.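

In this assay, the step with piperidin-1-yl in place of diethylamino on a saturated chain carbon bound to an aromatic carbon is a 1.3-fold lower number from compound 3 to compound 4 (0.10 log units; within the scatter), so the two groups cannot be told apart on this read-out. Compound 3 alone could not show that a six-membered non-aromatic ring at this place gives a value within the scatter of the open diethylamino group. Nothing given here offers an explanation for this result.

Steps involving compound 1 or compound 2 cannot be read, which leaves the carbamoylmethoxy and propylamino groups unplaced against the others. From the compounds shown here alone, how a morpholine or a carboxylic acid at this place would read remains open.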